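The compounds below may be only part of what the source reports. "The series", "measured", "known", "first", "only" and "open" are said of these compounds alone.

Going by the values given here, compound 1 `O=C(Nc1ccccc1C(F)(F)F)C1CCc2ccccc2N1C(=O)c1cccc(Cl)c1` is the only compound here with a numerical result: in a functional assay on NUGC-3 cells (Homo sapiens) for cytotoxicity, read by sulforhodamine B assay, with a stated time of 72 h (a higher number here means a weaker inhibitor of growth, a lower number a stronger inhibitor of growth), compound 1 gives 754 nM. Compound 2 `CC(=O)N1c2ccccc2CCC1C(=O)Nc1ccccc1C(F)(F)F` reaches only a limit of the assay, > 80000 nM in this assay. Among the compounds with values here, the single measured step, an at least 100-fold higher number from compound 1 to compound 2 (2.02 log units; beyond the scatter), swaps the group on the carbonyl carbon and sits at the limit of > 80000 nM in this assay, at which 1 of the 2 values shown sits.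

Compound 3 `O=C(Nc1ccccc1O)C1CCc2ccccc2N1C(=O)c1cccc(Cl)c1` changes a different place: hydroxy in place of trifluoromethyl on an aromatic carbon. Within the data shown here, no measured step touches this part of the shared core, so the only step on record gives no direct guide to the size or direction of the change in this assay for compound 3. The replacement is a modest one in bulk, and a change of at least moderate size in either direction would not be surprising. Compound 3 is therefore estimated at 2500 nM, with a range from 400 nM to 20000 nM. That estimate means a step of a 3.3-fold higher number from compound 1 to compound 3 (0.52 log units; beyond the scatter), expected to be a weakening.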

Compound 3, concentration for 50% growth inhibition: 11000 nM
Estimate against measurement, compound 3: 4.4-fold (0.64 log units) below, and the stated range covers the measured number.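

Replacing trifluoromethyl with hydroxy on an aromatic carbon ortho to a large group gives a 15-fold higher number from compound 1 to compound 3 (1.16 log units; beyond the scatter) in this assay. Going by these compounds alone, this shows that a second place on the molecule, one that no earlier step touched, also has a large effect on the number. The swap weakens growth inhibition, but compound 3 still gives a true number, 11000 nM, rather than a limit of the assay. Nothing measured here bears on why the number rises with this swap:.

Still open, as far as these compounds go, is whether a methoxy group, a fluorine atom or an amine in the same place would give a number closer to that of compound 1 or to that of compound 3. A single swap also cannot show whether the change comes from losing trifluoromethyl, from gaining hydroxy, or from both.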